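A chloro added to compound 3's core

The compounds below may be only part of what the source reports. "The series", "measured", "known", "first", "only" and "open" are said of these compounds alone.

Measured so far in a functional assay on MC-38 cells (Mus musculus) for antiproliferative activity, read by colorimetric assay and MTT assay; a lower number here means a stronger inhibitor, a higher number a weaker inhibitor:

Compound 1 `O=S(=O)(Nc1cccc2c(Cl)c[nH]c12)c1ccc(Cl)cc1` gives 0.28 ug/mL
Compound 2 `N#Cc1ccc(S(=O)(=O)Nc2ccc(Cl)c3c(Cl)c[nH]c23)cc1` gives 0.12 ug/mL
Compound 3 `Nc1ccc(S(=O)(=O)Nc2cccc3c(Cl)c[nH]c23)cc1` gives 0.23 ug/mL

Compound 3, at 0.23 ug/mL, stands in the middle of the three numbers and lies within the scatter of both other compounds. The next compound, compound 4 `Nc1ccc(S(=O)(=O)Nc2ccc(Cl)c3c(Cl)c[nH]c23)cc1`, keeps the amino group of compound 3 and has chloro in place of hydrogen on an aromatic carbon.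

Among the compounds with values here, only one measured step links two compounds directly, a 1.2-fold lower number from compound 1 to compound 3 (0.09 log units; within the scatter). It lies within the scatter, but it concerns a different change at a different place, so it says little about this one. Within the data shown here, no measured step isolates the added chloro. Among the measured compounds shown here, compound 2, at 0.12 ug/mL, is the only measured compound that already carries this chloro, and it also has a nitrile where compound 3 has amino. That value gives a weak hint towards a lower number in this assay, and no step beyond the scatter is expected. The expected change is small, a 1.4-fold lower number from compound 3 to compound 4 (0.13 log units; within the scatter). For compound 4 the estimated value is 0.17 ug/mL, with an expected range from 0.08 ug/mL to 0.35 ug/mL.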

Compound 4, half-maximal inhibitory concentration: 0.1 ug/mL
The estimate for compound 4 lay 1.7-fold (0.23 log units) above the measured number; the range from low to high includes it.
By their numbers in this assay, from the lowest: compounds 4, 2, 3 and 1 (each within the scatter of the next, the first and the last beyond it).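

In this assay the chloro in place of hydrogen on an aromatic carbon, ortho to a fused ring and para to a large group, gives a 2.3-fold lower number from compound 3 to compound 4 (0.36 log units; beyond the scatter) as a modest step, the first reading that isolates this change and the only step shown that lies beyond the scatter. With that chloro in place, amino in place of cyano gives a 1.2-fold lower number from compound 2 to compound 4 (0.08 log units; within the scatter) and stays within the scatter, just as amino in place of chloro gives a 1.2-fold lower number from compound 1 to compound 3 (0.09 log units; within the scatter) in the compounds without it, so among these four compounds the added chloro moves the number more than either swap of the group on the other aromatic ring. Nothing available explains why this chloro lowers the number.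

On these data alone, this step is a single example at a single place, so it remains open whether bromo, methyl or methoxy on the same carbon would give a similar step. The step has also been read only with the amino group present, which leaves its size alongside a nitrile or a chloro on the other aromatic ring open.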